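The source may report more compounds than this note shows. Statements on the series, on what has been measured and on what is new or still open speak of the compounds shown alone.

Working notes on the series. Among the compounds with values here, in a functional assay on ECa-109 cells (Homo sapiens) for antiproliferative activity, with a stated time of 72 h (on this read-out higher numbers stand for weaker inhibition and lower numbers for stronger inhibition), compound 1 `COc1cc(OC)c(C(=O)/C=C/c2ccccc2Cl)c(O)c1CN1CCCCC1` gives 2500 nM, the lower of the two numbers so far, while compound 2 `COc1cc(O)c2c(=O)cc(-c3ccccc3Cl)oc2c1CN1CCCCC1` gives 21500 nM, a gap beyond the scatter. Compound 3 `CCN(CC)Cc1c(OC)cc(OC)c(C(=O)/C=C/c2ccccc2Cl)c1O` remains unmeasured and differs from compound 1 as follows: diethylamino in place of piperidin-1-yl on a saturated chain carbon bound to an aromatic carbon. Within the data shown here, no measured pair shows this change, so the step expected in this assay is none beyond the scatter, with a slight lean towards a higher number. The estimated change is a 1.4-fold higher number from compound 1 to compound 3 (0.15 log units; within the scatter). Compound 3 is expected at 3500 nM, with an estimated range of 1500 nM to 8000 nM.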

Compound 3, half-maximal inhibitory concentration: 7100 nM
For compound 3 the middle estimate is 2.0-fold (0.31 log units) below the measured one; low and high end bracket the measured number.
By their numbers in this assay, from the lowest: compound 1; then compound 3; then compound 2.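

In this assay, diethylamino in place of piperidin-1-yl on a saturated chain carbon bound to an aromatic carbon gives a 2.8-fold higher number from compound 1 to compound 3 (0.45 log units; beyond the scatter) as a modest step, so this position responds to the choice of amine. This single pair favours the piperidin-1-yl of compound 1 over the open-chain diethylamino of compound 3. Nothing available accounts for the step.

As far as these compounds go, whether a ring at this position matters in itself remains open, and pyrrolidin-1-yl, morpholin-4-yl or dimethylamino on the same carbon would bear on that. Also open, from the compounds shown here alone, is whether the same change carries over to the core of compound 2.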